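Chain-end variation on a shared isoflavone-like core

The source may report more compounds than this note shows. Statements on the series, on what has been measured and on what is new or still open speak of the compounds shown alone.

Three measured compounds share one core, each carrying an ether chain on the same aromatic oxygen. Compound 1 `CCOC(=O)CCCCOc1ccc2c(=O)c(-c3ccc(O)cc3)coc2c1` gives 240 nM in an assay (Cricetulus griseus) for inhibition of aldehyde dehydrogenase, mitochondrial (Homo sapiens); a higher number here means a weaker inhibitor, a lower number a stronger inhibitor. Compound 2 `NCCCCOc1ccc2c(=O)c(-c3ccc(O)cc3)coc2c1` gives 250 nM in this assay, and compound 3 `C=CCOc1ccc2c(=O)c(-c3ccc(O)cc3)coc2c1` gives 180 nM. The three numbers lie within the usual scatter of one another: the step of a 1.0-fold higher number from compound 1 to compound 2 (0.02 log units; within the scatter) and the step of a 1.4-fold lower number from compound 2 to compound 3 (0.14 log units; within the scatter) are both within the scatter, as is a 1.3-fold lower number from compound 1 to compound 3 (0.12 log units; within the scatter). Compound 2 therefore stands among its neighbours without a separation that the measurement could resolve.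

Compound 4 `O=C(O)CCCCCCCCCOc1ccc2c(=O)c(-c3ccc(O)cc3)coc2c1` has not been measured. It differs from compound 2 by 5-carboxypentyl in place of amino on a saturated chain carbon, four bonds along the chain from an oxygen on an aromatic ring. The step from compound 1 to compound 2 exchanges one chain-end group for another at this same place and moved the number only within the scatter; the steps to compound 3, which shorten the chain to a vinyl group, were also within the scatter. Within the data shown here, nothing among the measured steps points to a direction, so compound 4 is expected to stay close to compound 2, with an estimated step of a 1.1-fold lower number from compound 2 to compound 4 (0.04 log units; within the scatter). For compound 4 the expected value is 230 nM, with a range from 100 nM to 550 nM.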

Compound 4, half-maximal inhibitory concentration: 50 nM
The estimate for compound 4 lay 4.6-fold (0.66 log units) above the measured number; measured number outside the range, below it.
By their numbers in this assay, from the lowest: compound 4; then compounds 3, 1 and 2 (each within the scatter of the next).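

Until this result, the chain end at this place, on a saturated chain carbon four bonds along the chain from an oxygen on an aromatic ring, had shown no resolvable response, but in this assay the 5-carboxypentyl group gives a separation the measurement can resolve: a 5.0-fold lower number from compound 2 to compound 4 (0.70 log units; beyond the scatter), and a 4.8-fold lower number from compound 1 to compound 4 (0.68 log units; beyond the scatter). The position is therefore not indifferent to what it carries, although this single change adds chain length and a carboxylic acid end together, so the two steps cannot assign the gain to either feature. Nothing measured here explains the lower number for compound 4.

The compounds shown leave open whether the carboxylic acid or the longer chain matters, a question that a carboxylic acid on a shorter chain, set against a longer chain ending in an amine or a plain alkyl group, would address. They also leave open whether the number keeps falling or turns back as the chain holding the carboxylic acid is made shorter or longer than in compound 4.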